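Methoxy in Place of Bromo on the Aniline Ring

A few compounds are considered here, and "the series" means these few. Any claim that something is new, unique, unknown or untested is made for them only; others in the source may bear on it.

Of the compounds shown here, two built on a shared core have been measured in an assay on isolated protein for inhibition of beta-glucuronidase (Bos taurus), read by spectrophotometry, with a stated time of 30 min; a higher number here means a weaker inhibitor, a lower number a stronger inhibitor. Compound 1 `Clc1ccc(Nc2nnc(-c3ccccc3)s2)cc1Cl` gives 6280 nM in this assay. Compound 2 `Brc1ccc(-c2nnc(Nc3cccc(Br)c3)s2)cc1` gives 17300 nM in this assay, the higher of the two numbers, and its nearest neighbour is compound 1, whose number is lower by a margin beyond the usual scatter. Compound 3 `COc1cccc(Nc2nnc(-c3ccc(Br)cc3)s2)c1` has not yet been measured. It differs from compound 2 in one place: methoxy in place of bromo on an aromatic carbon. Going by the values given here, no measured pair shows this exchange, so nothing in the data fixes the size of the step. The expectation in this assay is a step of modest size, more likely toward a higher number than a lower one, and the step of a 1.3-fold higher number from compound 2 to compound 3 (0.10 log units; within the scatter) is what that estimate means. For compound 3 the expected value in this assay is 22000 nM, with a range estimated from 7000 nM to 70000 nM.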

Compound 3, half-maximal inhibitory concentration: 31100 nM
Beside the measured number, compound 3's estimate is 1.4-fold (0.15 log units) below it, and the stated range covers the measured number.
By their numbers in this assay, from the lowest: compound 1; then compounds 2 and 3 (each within the scatter of the next).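

Going by these compounds alone, this is the first measured pair for the exchange of bromo for methoxy, on an aromatic carbon meta to a large group. In this assay the exchange gives a 1.8-fold higher number from compound 2 to compound 3 (0.25 log units; within the scatter) and leaves the two compounds indistinguishable, even though methoxy brings a hydrogen-bond acceptor that bromo lacks and has more heavy atoms. At this position, then, the pair gives no sign that bromo is needed for the activity seen, though it rests on this single exchange, and no accompanying measurement offers an explanation for the result.

Going by these compounds, whether an amine or a carboxylic acid on this aromatic carbon would shift the number beyond the scatter remains open. So does whether methoxy in place of bromo would give a similar result on the other aromatic ring of compound 2.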